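Fluoro for chloro on a small amide series

The source may hold more compounds than are shown below. What is called first, only, known or untested is meant among the compounds shown, and "the series" means these compounds.

In a functional assay on MCF7 cells (Homo sapiens) for antiproliferative activity, read by MTT assay, with a stated time of 48 h (on this read-out higher numbers stand for weaker inhibition and lower numbers for stronger inhibition), compound 1 `COc1cccc(C(=O)Nc2nnc(/C=C/c3cc(OC)c(OC)c(OC)c3Br)s2)c1` gives 170 nM, compound 2 `COc1ccc(C(=O)Nc2nnc(/C=C/c3cc(OC)c(OC)c(OC)c3Br)s2)cc1` gives 560 nM and compound 3 `COc1cc(/C=C/c2nnc(NC(=O)c3cccc(Cl)c3)s2)c(Br)c(OC)c1OC` gives 230 nM. Compound 3 thus stands level with compound 1, while compound 2 stands apart. The measurements show a 2.4-fold lower number from compound 2 to compound 3 (0.39 log units; beyond the scatter), and the remaining pair shows a 3.3-fold higher number from compound 1 to compound 2 (0.52 log units; beyond the scatter).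

Compound 4 `COc1cc(/C=C/c2nnc(NC(=O)c3cccc(F)c3)s2)c(Br)c(OC)c1OC` keeps the shared core and differs from compound 3 by fluoro in place of chloro on an aromatic carbon, meta to a large group. Among the measured compounds shown here, no measured pair exchanges one halogen for another, so the evidence is indirect. The closest guide is the replacement of methoxy by chloro on that aromatic carbon, a 1.4-fold higher number from compound 1 to compound 3 (0.13 log units; within the scatter). The two larger steps both involve compound 2, whose group sits elsewhere on the ring, and compound 4 does not share that placement.

A step beyond the scatter is therefore not expected in this assay, and the expected change is a 1.1-fold higher number from compound 3 to compound 4 (0.04 log units; within the scatter). For compound 4 the estimated value is 250 nM, with an expected range of 110 nM to 550 nM.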

Compound 4, half-maximal inhibitory concentration: 340 nM
The estimate for compound 4 lay 1.4-fold (0.13 log units) below the measured number; measured number inside the range.
By their numbers in this assay, from the lowest: compounds 1, 3, 4 and 2 (each within the scatter of the next, the first and the last beyond it).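

In this assay, the exchange of one halogen for another on this aromatic carbon, meta to a large group, can now be read directly (a 1.5-fold higher number from compound 3 to compound 4 (0.17 log units; within the scatter)), and on this read-out 3-fluorophenyl is not told apart from 3-chlorophenyl. Compound 4 also lies within the scatter of the two methoxy compounds (a 2.0-fold higher number from compound 1 to compound 4 (0.30 log units; within the scatter) and a 1.6-fold lower number from compound 2 to compound 4 (0.22 log units; within the scatter)), even though compound 1 and compound 2 lie beyond the scatter of each other, so its number separates it from neither. Nothing available explains these numbers.

Going by these compounds, whether a quite different group on this carbon, such as an amine or a carboxylic acid, would stay equally close remains open. The only change of placement shown involves methoxy, so whether either halogen would respond to placement as methoxy does also remains open.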